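A few compounds are considered here, and "the series" means these few. Any claim that something is new, unique, unknown or untested is made for them only; others in the source may bear on it.

Measured compounds:
compound 1 `C=C1C[C@]23C[C@@]1(O)CC[C@H]2c1ccc(OS(=O)(=O)c2ccc(C)cc2)c(C)c1[C@@H]3Cn1cc(-c2ccc(Cl)cc2)nn1`, > 20000 nM
compound 2 `C=C1C[C@]23C[C@@]1(O)CC[C@H]2c1ccc(OS(=O)(=O)c2ccc(C)cc2)c(C)c1[C@@H]3Cn1cc(-c2ccc(Br)cc2)nn1`, > 20000 nM
compound 3 `C=C1C[C@]23C[C@@]1(O)CC[C@@H]2c1cccc(C)c1[C@@H]3Cn1cc(-c2ccc(Cl)cc2)nn1`, > 20000 nM

In a functional assay on HL-60 cells (Homo sapiens) for cytotoxicity, read by MTT assay, with a stated time of 4 days (a lower number here means a stronger inhibitor, a higher number a weaker inhibitor), compound 1 reaches only a limit, > 20000 nM. Compound 2 likewise gives only a limit, > 20000 nM. Compound 3 too stays at a limit, > 20000 nM. The change from compound 1 to compound 2 is bromo in place of chloro on an aromatic carbon, and the resulting step that the two limits leave unreadable from compound 1 to compound 2 cannot be sized, because of the limit of > 20000 nM in this assay, at which 3 of the 3 values shown sit. The cores of compound 1 and compound 3 differ, but that difference is not broken down here; their values show only that both sit at the same limit.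

Compound 4 `C=C1C[C@]23C[C@@]1(O)CC[C@@H]2c1cccc(C)c1[C@@H]3Cn1cc(-c2ccc(Br)cc2)nn1` is not yet measured. It differs from compound 3 by bromo in place of chloro on an aromatic carbon, the same change as that made from compound 1 to compound 2, at the same kind of place. Since that earlier change left both partners at the limit, the estimated step that the limit leaves unreadable from compound 3 to compound 4 is expected to be small. For compound 4 the value expected in this assay is 30000 nM, most likely again a limit, with the estimate ranging from 10000 nM to 100000 nM.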

Compound 4, half-maximal inhibitory concentration: > 20000 nM
Compound 4 was reported as a limit; the forecaster's own chance of this, stated with the estimate: 90%; the middle value does not contradict the limit.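

In this assay compound 4 gives > 20000 nM, which is a limit. No size can be read for the step between compound 3 and compound 4, because both sit at a limit: the limit of > 20000 nM in this assay, at which 4 of the 4 values shown sit.

The compounds shown leave open whether the 4-chlorophenyl and 4-bromophenyl partners differ at all in this assay, and how the two cores compare.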